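Trading pyrrolidin-1-yl for 1H-pyrazol-1-yl

The source may hold more compounds than are shown below. What is called first, only, known or untested is meant among the compounds shown, and "the series" means these compounds.

Of the compounds shown here, two have been measured so far in a functional assay on XF498 cells (Homo sapiens) for cytotoxicity (a higher number here means a weaker inhibitor, a lower number a stronger inhibitor), on this series. Compound 1 (`Cc1nn(C)c(Oc2ccc(Cl)cc2)c1/C=N/OCc1ccc(C(=O)OC(C)(C)C)cc1`) gives 0.02 ug/mL there, and compound 2 (`Cc1nn(C)c(N2CCCC2)c1/C=N/OCc1ccc(C(=O)OC(C)(C)C)cc1`) gives 0.12 ug/mL as the higher of the two numbers. Compound 3 (`Cc1nn(C)c(-n2cccn2)c1/C=N/OCc1ccc(C(=O)OC(C)(C)C)cc1`) carries 1H-pyrazol-1-yl in place of pyrrolidin-1-yl on an aromatic carbon of the shared core. Among the measured compounds shown here, one measured step bears on this place: pyrrolidin-1-yl in place of 4-chlorophenoxy gave a 6.0-fold higher number from compound 1 to compound 2 (0.78 log units; beyond the scatter) on that same carbon. Compound 1 at 0.02 ug/mL holds an aromatic ring in its group, as the entering group does, so a partial move toward a lower number is expected, smaller than that step. The estimated step is a 2.4-fold lower number from compound 2 to compound 3 (0.38 log units; beyond the scatter) on this reasoning. The estimate for compound 3 is 0.05 ug/mL as the expected value, with 0.012 ug/mL to 0.2 ug/mL as the expected range.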

Compound 3, half-maximal inhibitory concentration: 5.51 ug/mL
For compound 3 the middle estimate is 110-fold (2.04 log units) below the measured one; measured number outside the range, above it.
By their numbers in this assay, from the lowest: compound 1; then compound 2; then compound 3.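

In this assay, the position proves far more sensitive than the earlier pair suggested: 1H-pyrazol-1-yl in place of pyrrolidin-1-yl gives a 46-fold higher number from compound 2 to compound 3 (1.66 log units; beyond the scatter), even though both groups are five-membered rings with the same heavy-atom count. An aromatic ring in the group on this carbon does not by itself keep the number low, as compound 1 and compound 3 both carry one, yet replacing 4-chlorophenoxy with 1H-pyrazol-1-yl gives a 280-fold higher number from compound 1 to compound 3 (2.44 log units; beyond the scatter). Nothing available explains the size of either step.

The three compounds leave open whether the extra ring nitrogen of 1H-pyrazol-1-yl or the absence of the phenoxy oxygen matters more here. Groups such as pyrrol-1-yl, imidazol-1-yl, or unsubstituted phenoxy on the same carbon would separate these possibilities.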